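Replacing the 1-methyl-1H-pyrrol-2-yl group of compound 2

This account rests on a few compounds, and the source may have more. Where it says the series, first, only, none or still open, it means among the compounds named here.

In a functional assay on CCRF-CEM cells (Homo sapiens) for cytotoxicity, with a stated time of 72 h (a lower number here means a stronger inhibitor, a higher number a weaker inhibitor), compound 1 `CCOC(=O)/C=C/C=C/c1ccc[nH]1` gives > 10000 nM, which is a limit. Compound 2 `CCOC(=O)/C=C/C=C/C=C/C=C/c1cccn1C` gives > 10000 nM, also a limit, so no number exists for its standing. Within the data shown here, compound 3 `O=C(/C=C/C=C/C=C/c1ccc[nH]1)OCc1ccccc1` gives 830 nM, the only actual number in the set. Compound 4 `CCOC(=O)/C=C/C=C/C=C/C=C/c1[nH]ccc1Cl` comes from compound 2 by one change: a group of 6 heavy atoms (4 carbon, 1 nitrogen, 1 chlorine; one five-membered aromatic ring with 1 hetero atom) in place of a group of 6 heavy atoms (5 carbon, 1 nitrogen; one five-membered aromatic ring with 1 hetero atom), on a double-bonded chain carbon bound to a double-bonded chain carbon. Among the measured compounds shown here, no measured step of this kind is available, so the expectation rests only loosely on compound 3 at 830 nM. A move toward stronger inhibition is expected, of uncertain size, and the estimated step is an at least 3.3-fold lower number from compound 2 to compound 4 (0.52 log units; beyond the scatter). For compound 4 the estimated value is 3000 nM, with an expected range of 600 nM to 10000 nM.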

Compound 4, half-maximal inhibitory concentration: 270 nM
Compound 4: middle estimate off by 11-fold (1.05 log units), on the high side, outside the stated range (below it).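

In this assay, among these compounds, the change on this chain carbon gives an at least 37-fold lower number from compound 2 to compound 4 (1.56 log units; beyond the scatter), the first step that can be read, and it shows that the group at this place alone can bring measurable cytotoxicity to the chain of compound 2. The true size of the step stays unknown: the limit of > 10000 nM in this assay, at which 2 of the 4 values shown sit.

The step joins the loss of the ring's methyl group and the gain of chlorine, and the compounds shown do not separate the two. As far as these compounds go, whether bromine in place of the chlorine, or a shorter chain carrying the same ring, would hold the activity of compound 4 also stays open.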